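Oxolane in Place of Cyclopentyl on the Amide Carbonyl

The compounds below may be only part of what the source reports. "The series", "measured", "known", "first", "only" and "open" are said of these compounds alone.

Compound 1 `Cc1cc(C(=O)NCc2ccncc2)nn1Cc1cc(Cl)ccc1OCc1ccccc1` gives > 3.7 in a physicochemical assay for lipophilicity, at pH 7.4; on this read-out higher numbers stand for higher lipophilicity and lower numbers for lower lipophilicity; that value is a limit of the assay and not a number. Compound 2 `Cc1cc(NC(=O)C2CCCC2)nn1Cc1cc(Cl)ccc1OCc1ccccc1` gives 3.5 in this assay.

Within the data shown here, compound 2 thus holds the only number in this assay, the other value being a limit (the limit of > 3.7 in this assay, at which 1 of the 2 values shown sits). Among the measured compounds shown here, the single measured step, a number at least 0.20 log units lower from compound 1 to compound 2 (that floor lies within the scatter), alters a different part of the structure and does not bear on the change to compound 3 `Cc1cc(NC(=O)C2CCOC2)nn1Cc1cc(Cl)ccc1OCc1ccccc1`, which is oxolan-3-yl in place of cyclopentyl on a carbonyl carbon. For the measured compounds named here, no measured step guides this change, so the expectation rests on the structural difference alone. The step is expected to be a number 1.00 log units lower from compound 2 to compound 3 (beyond the scatter). Compound 3 is estimated at 2.5, within 1.9 to 3.1.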

Compound 3, distribution coefficient: > 3.7
Compound 3: a limit, no number (the forecaster's own chance of this, stated with the estimate: 2%); middle value at least 1.20 log units away from the limit.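

In this assay, oxolan-3-yl in place of cyclopentyl on a carbonyl carbon gives a number at least 0.20 log units higher from compound 2 to compound 3 (that floor lies within the scatter), so the one hydrogen-bond acceptor that enters here brings no printed fall in the read-out. For compound 3, the value > 3.7 is a limit of the assay and not a number. The step from compound 1 to compound 3 cannot be read, and limits now make up most of the values shown: the limit of > 3.7 in this assay, at which 2 of the 3 values shown sit.

Left open is how far compound 3 truly lies from compound 2. Also open, on these data alone, is whether an oxan-4-yl ring or a piperidine amine on this carbonyl carbon would give a number in this assay rather than a limit.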